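Lengthening the Amide-Side Chain: Ethyl to Propyl

The source may report more compounds than this note shows. Statements on the series, on what has been measured and on what is new or still open speak of the compounds shown alone.

In a functional assay on CHO cells for antagonist activity at B1 bradykinin receptor (Macaca fascicularis), read by FLIPR and calcium flux (on this read-out lower numbers stand for stronger inhibition and higher numbers for weaker inhibition), compound 1 `CN1CCC(N2CCN(C(=O)CN(C)C(=O)c3nc4ccccc4n3Cc3ccccc3)CC2)CC1` gives 268 nM, while compound 2 `CCN(CC(=O)N1CCN(C2CCN(C)CC2)CC1)C(=O)c1nc2ccccc2n1Cc1ccccc1` gives 16 nM, the lowest of the two numbers shown; the step of a 17-fold lower number from compound 1 to compound 2 (1.22 log units; beyond the scatter) was large. Compound 3 `CCCN(CC(=O)N1CCN(C2CCN(C)CC2)CC1)C(=O)c1nc2ccccc2n1Cc1ccccc1` carries the change (methyl in place of hydrogen on a saturated chain carbon, two bonds along the chain from an amide-type nitrogen), the same kind of change as before but one bond further out. Going by the values given here, only that earlier step bears on it, and it was large, yet a second lengthening need not repeat it, so a smaller downward step is expected, a 1.6-fold lower number from compound 2 to compound 3 (0.20 log units; within the scatter), with no step beyond the scatter also plausible. Compound 3 is therefore estimated at 10 nM, ranging from 3 nM to 40 nM.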

Compound 3, half-maximal inhibitory concentration: 18 nM
Compound 3: middle estimate off by 1.8-fold (0.26 log units), on the low side; measured number inside the range.
By their numbers in this assay, from the lowest: compounds 2 and 3 (each within the scatter of the next); then compound 1.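

In this assay, lengthening ethyl to propyl gives a 1.1-fold higher number from compound 2 to compound 3 (0.05 log units; within the scatter) and so does not repeat the large drop that came with the first added carbon. Propyl keeps the advantage over the shorter chain of compound 1, with a 15-fold lower number from compound 1 to compound 3 (1.17 log units; beyond the scatter) on record, so at this position the number stays level once the chain reaches ethyl. Nothing measured here offers a reason for this levelling.

Going by these compounds, whether a butyl chain or a branched isopropyl group would hold the same level remains open. So does the effect of an amine or a carboxylic acid at the chain end.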